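Swapping hydroxy for fluoro on a strongly active thiophene

A few compounds are considered here, and "the series" means these few. Any claim that something is new, unique, unknown or untested is made for them only; others in the source may bear on it.

Measured so far:
compound 1 `N#Cc1c(Nc2ccc(O)cc2)sc2ccccc12` — 2%
compound 2 `COc1cc2sc(Nc3ccc(O)cc3)c(C#N)c2cc1OC` — 73%

In a functional assay on HUVEC cells (Homo sapiens), read by fluorescence and microscopy, with a stated time of 6 h, tested at 250 nM (on this read-out lower numbers stand for a stronger effect and higher numbers for a weaker effect at the one concentration tested), compound 1 gives 2%, the lowest of the two numbers seen, while compound 2 gives 73%, a number far higher than that of compound 1 and well beyond the scatter. Compound 1 therefore stands as the clearly stronger of the two measured compounds.

The new compound 3 `N#Cc1c(Nc2ccc(F)cc2)sc2ccccc12` keeps the core of compound 1 and changes one spot: fluoro in place of hydroxy on an aromatic carbon. Going by the values given here, no step between two measured compounds shows what such a swap does, so the expectation rests on the strong result of compound 1 alone and is uncertain. The change is small in size, so a moderate weakening rather than a large one is expected in this assay.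

For compound 3 an activity of 25% is estimated, within 3% to 65%. This estimate means a step from compound 1 to compound 3 of a number 23 percentage points higher from compound 1 to compound 3 (beyond the scatter) is expected.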

Compound 3, a percentage reported as activity, at one concentration (the size of the read-out at that concentration, not a potency): 58%
Beside the measured number, compound 3's estimate is 33 percentage points below it, and the stated range covers the measured number.
By their numbers in this assay, from the lowest: compound 1; then compound 3; then compound 2.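

In this assay, replacing hydroxy with fluoro on this aromatic carbon gives a number 56 percentage points higher from compound 1 to compound 3 (beyond the scatter), so the effect at this one concentration depends strongly on the group at this spot. With the rest of the molecule unchanged, this single swap replaces a near-complete effect with a much weaker one. The two groups are not interchangeable here, even though each adds only one heavy atom. The swap also takes away one hydrogen-bond donor and one hydrogen-bond acceptor, but nothing measured here explains the size of the step.

One swap cannot show which difference between hydroxy and fluoro matters. The compounds shown leave open how an amine or a carboxylic acid would read at this same spot, and therefore whether anything other than hydroxy can keep the strong result.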